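A few compounds are considered here, and "the series" means these few. Any claim that something is new, unique, unknown or untested is made for them only; others in the source may bear on it.

Three measured compounds share one core and differ only in the group on the aromatic nitrogen. In an assay on Prostate gland for inhibition of steroid 5-alpha-reductase (Rattus norvegicus) (on this read-out lower numbers stand for stronger inhibition and higher numbers for weaker inhibition), compound 1 `CCCCCCn1ccc2cc(/C(C)=C/C(=O)Nc3ccccc3OCCCC(=O)O)ccc21` gives 77 nM. Compound 2 `CCCC(C)n1ccc2cc(/C(C)=C/C(=O)Nc3ccccc3OCCCC(=O)O)ccc21` gives 7.8 nM in this assay, a change of a 9.9-fold lower number from compound 1 to compound 2 (0.99 log units; beyond the scatter). Compound 3 `CCCCC(C)n1ccc2cc(/C(C)=C/C(=O)Nc3ccccc3OCCCC(=O)O)ccc21` gives 6 nM in this assay, a change of a 13-fold lower number from compound 1 to compound 3 (1.11 log units; beyond the scatter), while the move a 1.3-fold lower number from compound 2 to compound 3 (0.11 log units; within the scatter) lies within the scatter, so compound 3 and compound 2 cannot be set apart. Compound 4 `CCCCc1ccc(Cn2ccc3cc(/C(C)=C/C(=O)Nc4ccccc4OCCCC(=O)O)ccc32)cc1` carries the change (4-butylbenzyl in place of 1-methylpentyl on an aromatic nitrogen). Within the data shown here, the measured steps show only that the two branched chains gave lower numbers than hexyl; no step involves an aromatic ring in this position, so the effect of the 4-butylbenzyl group has no direct precedent. With the branched chain gone, the estimate for compound 4 is a step of a 5.0-fold higher number from compound 3 to compound 4 (0.70 log units; beyond the scatter) in this assay, toward a higher number but with wide uncertainty. Compound 4 is expected to give about 30 nM in this assay, within a range from 6 nM to 150 nM.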

Compound 4, half-maximal inhibitory concentration: 100 nM
Compound 4: middle estimate off by 3.3-fold (0.52 log units), on the low side; low and high end bracket the measured number.
By their numbers in this assay, from the lowest: compounds 3 and 2 (each within the scatter of the next); then compounds 1 and 4 (each within the scatter of the next).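

In this assay the 4-butylbenzyl group gives up what the branched chains had gained on this aromatic nitrogen, with a 17-fold higher number from compound 3 to compound 4 (1.22 log units; beyond the scatter) and a 13-fold higher number from compound 2 to compound 4 (1.11 log units; beyond the scatter) as the two steps. Set against the unbranched hexyl group, it shows a 1.3-fold higher number from compound 1 to compound 4 (0.11 log units; within the scatter) and so compound 4 and compound 1 cannot be set apart, which means that this larger group with its aromatic ring offers no advantage over hexyl here. Nothing at hand explains why the number rises.

From the compounds shown here alone, it remains open whether the butyl group on the ring plays any part, which a plain benzyl group on the same nitrogen would test. A 1-phenylethyl group would show whether an aromatic ring can be combined with the branched carbon of compound 2 and compound 3.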